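Changing the group on a ring amine nitrogen

This account rests on a few compounds, and the source may have more. Where it says the series, first, only, none or still open, it means among the compounds named here.

Measured so far in a physicochemical assay for solubility (on this read-out lower numbers stand for lower solubility and higher numbers for higher solubility), for each compound:
Compound 1 `CN(C)c1ccc(C(=O)N2CCC(NS(=O)(=O)c3cc(S(=O)(=O)c4ccccc4)ccc3C(F)(F)F)CC2)cn1` gives 12500 nM
Compound 2 `O=C(O)c1cccc(S(=O)(=O)N2CCC(NS(=O)(=O)c3cc(S(=O)(=O)c4ccccc4)ccc3C(F)(F)F)CC2)c1` gives 12500 nM

Among the measured compounds shown here, only two compounds have numbers so far, and compound 1 stands level with compound 2 at 12500 nM on this scale. Next comes compound 3 `O=C(O)c1ccc(N2CCC(NS(=O)(=O)c3cc(S(=O)(=O)c4ccccc4)ccc3C(F)(F)F)CC2)cc1` which keeps the core of compound 2 and differs at one place, on an amine nitrogen in a ring. The change is 4-carboxyphenyl in place of (3-carboxyphenyl)sulfonyl on an amine nitrogen in a ring and it puts 4-carboxyphenyl in place of (3-carboxyphenyl)sulfonyl.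

For the measured compounds named here, one measured step touches that same place, no change at the digits printed from compound 1 to compound 2 (within the scatter) and it lies within the scatter, even though a very different group entered there. Going by the values given here, a single step is a thin guide, and no measured compound yet carries 4-carboxyphenyl at this position. The expectation in this assay is therefore no step beyond the scatter, with an estimated no change at the digits printed from compound 2 to compound 3 (within the scatter) for this change. For compound 3 the estimated value is 12500 nM with an expected range from 6000 nM to 16000 nM in this measurement.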

Compound 3, solubility: 25000 nM
Estimate against measurement, compound 3: 2.0-fold (0.30 log units) below; measured number outside the range, above it.
By their numbers in this assay, from the lowest: compounds 1, 2 and 3 (each within the scatter of the next).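

Compound 3 brings a third, quite different group onto the amine nitrogen in the ring, and in this assay the swap to 4-carboxyphenyl gives a 2.0-fold higher number from compound 2 to compound 3 (0.30 log units; within the scatter). Measured against the (6-(dimethylamino)pyridin-3-yl)carbonyl group, the same group gives a 2.0-fold higher number from compound 1 to compound 3 (0.30 log units; within the scatter), so all three compounds now lie within the scatter of one another, even though the entering group has fewer heavy atoms than (3-carboxyphenyl)sulfonyl and no sulfur. Nothing in the data explains why these three groups read so much alike.

The step from compound 2 to compound 3 alters two features at once, the sulfonyl link and the place named for the carboxylic acid on the phenyl ring, so a 3-carboxyphenyl group joined straight to the ring nitrogen would be needed to pull those two apart. A plain phenyl group with no carboxylic acid, or a carboxylic acid on a longer chain, also stands outside these compounds, which leaves open whether this position stays as flat on this read-out with such groups.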